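Amide-end variation in the benzimidazolylmethyl piperazine series

The source may report more compounds than this note shows. Statements on the series, on what has been measured and on what is new or still open speak of the compounds shown alone.

Measured so far:
compound 1 `CCn1c(CN2CCN(C(=O)C3CC3)CC2)nc2ccccc21` — 20.8%
compound 2 `Cc1cccc(Cn2c(CN3CCN(C(=O)C4CCCC4)CC3)nc3ccccc32)c1` — 67.5%
compound 3 `O=C(C1CC1)N1CCN(Cc2nc3ccccc3n2Cc2ccccc2F)CC1` — 40.7%

In an assay on isolated protein for inhibition of aldehyde dehydrogenase 1A1 (Homo sapiens), read by spectrophotometry, tested at 10 uM (on this read-out higher numbers stand for more inhibition at the one concentration tested (going by the name of the read-out) and lower numbers for less inhibition), compound 2 stands highest of the three numbers, beyond the scatter above both compound 3 and compound 1. Among the measured compounds shown here, the one measured step, a number 19.9 percentage points higher from compound 1 to compound 3 (beyond the scatter), concerns the group on the aromatic nitrogen, not the amide end. Compound 1 and compound 2 differ in two places at once, so their values show only that the larger combination reads higher.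

Compound 4 `Cc1cccc(Cn2c(CN3CCN(C(=O)c4ccncc4)CC3)nc3ccccc32)c1` is the next step: pyridin-4-yl in place of cyclopentyl on a carbonyl carbon. For the measured compounds named here, no measured step touches the carbonyl substituent, so no direction can be taken from the series. The estimate for compound 4 is 50%, range 20% to 80%, meaning an expected step of a number 17.5 percentage points lower from compound 2 to compound 4 (beyond the scatter), with wide uncertainty.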

Compound 4, a percentage reported as inhibition, at one concentration (the size of the read-out at that concentration, not a potency): 20.6%
Beside the measured number, compound 4's estimate is 29.4 percentage points above it; the range from low to high includes it.
By their numbers in this assay, from the lowest: compounds 4 and 1 (each within the scatter of the next); then compound 3; then compound 2.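

Among the compounds shown here, the carbonyl substituent is the first position with a measured step of its own. In this assay, pyridin-4-yl in place of cyclopentyl gives a large change, a number 46.9 percentage points lower from compound 2 to compound 4 (beyond the scatter), with the group on the aromatic nitrogen held fixed. No available evidence bears on the reason for this step.

On these data alone, whether the drop follows the ring nitrogen of pyridin-4-yl or the aromatic ring as a whole remains open. A phenyl or cyclohexyl group on the carbonyl carbon would help separate the two.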